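The source may report more compounds than this note shows. Statements on the series, on what has been measured and on what is new or still open speak of the compounds shown alone.

In a functional assay on A549 cells (Homo sapiens) for antiproliferative activity, read by sulforhodamine B assay, with a stated time of 72 h (a lower number here means a stronger inhibitor, a higher number a weaker inhibitor), compound 1 `CC(C)C[C@H](NC(=O)CSc1cc(NS(=O)(=O)c2ccccc2)c2ccccc2c1O)B(O)O` gives 5940 nM, compound 2 `CC(C)C[C@H](NC(=O)CSc1cc(NS(=O)(=O)c2ccc(Cl)cc2)c2ccccc2c1O)B(O)O` gives 6900 nM, and compound 3 `CC(C)C[C@H](NC(=O)CCSc1cc(NS(=O)(=O)c2ccccc2)c2ccccc2c1O)B(O)O` gives 7800 nM. The value of compound 3 thus lies within the usual scatter of the other two values, and these three numbers do not separate the compounds.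

Compound 4 `CC(C)C[C@H](NC(=O)CCSc1cc(NS(=O)(=O)c2cccs2)c2ccccc2c1O)B(O)O` differs from compound 3 at a single place: thiophen-2-yl in place of phenyl on a sulfonyl sulfur. In words, thiophen-2-yl stands in place of phenyl on a sulfonyl sulfur.

Among the compounds with values here, no compound measured so far carries thiophen-2-yl, so the data hold no direct measure of this exchange. Within the data shown here, the only measured step on the group attached to that sulfonyl sulfur is a chloro in place of hydrogen on an aromatic carbon, a 1.2-fold higher number from compound 1 to compound 2 (0.07 log units; within the scatter). Among the measured compounds shown here, with that small step as the only guide, the expected change is a 1.1-fold lower number from compound 3 to compound 4 (0.05 log units; within the scatter), and no shift beyond the scatter is expected in this assay. Compound 4 is estimated at 7000 nM, with an expected range of 3500 nM to 14000 nM.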

Compound 4, half-maximal inhibitory concentration: 5930 nM
Compound 4: middle estimate off by 1.2-fold (0.07 log units), on the high side; the range from low to high includes it.
By their numbers in this assay, from the lowest: compounds 4, 1, 2 and 3 (each within the scatter of the next).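

Thiophen-2-yl in place of phenyl on a sulfonyl sulfur gives a 1.3-fold lower number from compound 3 to compound 4 (0.12 log units; within the scatter) in this assay and stays within the scatter. The earlier compounds shown here showed only a chloro added to the phenyl at this place, whereas this step replaces the six-membered aromatic ring with a five-membered one that contains sulfur, and the assay still does not separate the two compounds. No measured evidence is available to explain the size of this step.

Going by these compounds, it remains open whether an amine, a carboxylic acid or a simple methyl on the sulfonyl sulfur would move the number beyond the scatter. On these data alone, it also remains open whether thiophen-2-yl would give a similar step on the core of compound 1.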